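Swapping a side chain for fluoro on compound 2

A few compounds are considered here, and "the series" means these few. Any claim that something is new, unique, unknown or untested is made for them only; others in the source may bear on it.

Measured in an ADME assay on Caco-2 cells (Homo sapiens) for permeability, in the apical to basolateral direction; a higher number here means that the compound crosses the layer faster, a lower number that the compound crosses the layer more slowly:
compound 1 `Cn1nc2c(=O)n(CC3(O)CCN(Cc4ccc(-c5cnco5)cc4Cl)CC3)cnc2c1-c1ccc(CN)cc1`: 0.86 10^-6 cm/s
compound 2 `Cn1nc2c(=O)n(CC3(O)CCN(Cc4ccc(-c5ccco5)cc4Cl)CC3)cnc2c1-c1ccc(CNCCO)cc1`: 0.36 10^-6 cm/s
compound 3 `Cn1nc2c(=O)n(CC3(O)CCN(Cc4ccc(-c5ccco5)cc4Cl)CC3)cnc2c1-c1ccc(CNS(C)(=O)=O)cc1`: 50 10^-6 cm/s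

Of these three, compound 2 gives the lowest number, 0.36 10^-6 cm/s. It lies below compound 1 and far below compound 3.

Compound 4 `Cn1nc2c(=O)n(CC3(O)CCN(Cc4ccc(-c5ccco5)cc4Cl)CC3)cnc2c1-c1ccc(F)cc1` has not yet been measured in this assay. Its structure departs from that of compound 2 as follows: fluoro in place of ((2-hydroxyethyl)amino)methyl on an aromatic carbon. Put simply, compound 4 carries fluoro where compound 2 carries its side chain.

For the measured compounds named here, only one measured step bears on this change. There, methylsulfonyl takes the place of 2-hydroxyethyl on an amine nitrogen, and the result is a 140-fold higher number from compound 2 to compound 3 (2.14 log units; beyond the scatter). That step is large and lies well beyond the scatter. Compound 1 differs from compound 2 in more than one place, so it offers no clean comparison. The change in compound 4 also removes the 2-hydroxyethyl group, but it removes the amine nitrogen too, so this single step is only a rough guide. A large rise is therefore expected, probably somewhat smaller than the step to compound 3, and the range is kept wide.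

The estimated change is a 69-fold higher number from compound 2 to compound 4 (1.84 log units; beyond the scatter). For compound 4 the estimate is 25 10^-6 cm/s, with an expected range of 6 10^-6 cm/s to 70 10^-6 cm/s.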

Compound 4, apparent permeability: 6.84 10^-6 cm/s
Compound 4: middle estimate off by 3.7-fold (0.56 log units), on the high side; measured number inside the range.
By their numbers in this assay, from the lowest: compound 2; then compound 1; then compound 4; then compound 3.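

In this assay, replacing the whole side chain with a single fluoro gives a 19-fold higher number from compound 2 to compound 4 (1.28 log units; beyond the scatter) and shows that this aromatic carbon responds strongly to losing the chain outright, whereas the earlier step changed only the group on the chain's nitrogen. The other comparison runs the opposite way, with a 7.3-fold lower number from compound 3 to compound 4 (0.86 log units; beyond the scatter) showing that the smallest group here does not give the highest number. Compound 2 and compound 3 both carry chains at this carbon yet fall on either side of compound 4, so among these three compounds the size of the group alone does not set the order, and what the chain carries at its far end matters at least as much. Nothing shown here offers a measured explanation for these differences.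

Still open, from the compounds shown here alone, is where other small groups at this aromatic carbon, such as chloro or methoxy, would fall relative to compound 4. Going by these compounds, it is equally open how a chain ending in a carboxylic acid, or a longer chain ending in a sulfonamide, would compare with compound 3.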